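Notes on a side-chain change ahead of compound 3

The source may report more compounds than this note shows. Statements on the series, on what has been measured and on what is new or still open speak of the compounds shown alone.

Measured so far in a functional assay; on this read-out lower numbers stand for stronger inhibition and higher numbers for weaker inhibition:
compound 1, `CC(C)C[C@@H]1NC(=O)[C@H](CS)NC1=O`: 100000 nM
compound 2, `CC(C)C[C@@H]1NC(=O)[C@H](Cc2cnc[nH]2)NC1=O`: 850000 nM

Among the compounds with values here, compound 2 stands highest of the two numbers in hand; the only neighbour is compound 1, and the one measured step, an 8.5-fold higher number from compound 1 to compound 2 (0.93 log units; beyond the scatter), came from 1H-imidazol-5-yl in place of sulfanyl on a saturated chain carbon bound to a saturated ring carbon. Both compounds sit in the weak range of this read-out.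

Compound 3, `CC(C)C[C@@H]1NC(=O)[C@H](CCC(=O)O)NC1=O`, keeps the shared core and changes the same place once more: carboxymethyl in place of 1H-imidazol-5-yl on a saturated chain carbon bound to a saturated ring carbon. The step that bears on it is the single one above, an 8.5-fold higher number from compound 1 to compound 2 (0.93 log units; beyond the scatter), which touched this position and was modest. Within the data shown here, no measured compound carries carboxymethyl, so the direction of the new step rests on that step alone.

The expectation is a step back toward the number of compound 1, a 2.8-fold lower number from compound 2 to compound 3 (0.45 log units; beyond the scatter), rather than a further rise. Compound 3 is therefore estimated at 300000 nM, with a range from 80000 nM to 1500000 nM, and a fair chance that only a limit is returned.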

Compound 3, half-maximal inhibitory concentration: 80000 nM
For compound 3 the middle estimate is 3.8-fold (0.57 log units) above the measured one, within the range that was stated.
By their numbers in this assay, from the lowest: compounds 3 and 1 (each within the scatter of the next); then compound 2.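

In this assay, carboxymethyl in place of 1H-imidazol-5-yl on a saturated chain carbon bound to a saturated ring carbon gives an 11-fold lower number from compound 2 to compound 3 (1.03 log units; beyond the scatter) and thus shows that this position can move the number in both directions, with a large step on the way back. Carboxymethyl in place of sulfanyl at the same place gives a 1.3-fold lower number from compound 1 to compound 3 (0.10 log units; within the scatter) so compound 1 and compound 3 cannot be separated on this read-out, even though sulfanyl and carboxymethyl are different groups, and compound 2 alone stands apart as the weakest of the three. The evidence at hand offers no explanation for either step.

The compounds shown leave open whether the high number of compound 2 belongs to 1H-imidazol-5-yl specifically or would also appear with another ring, such as phenyl, at this place. They also leave open whether an amine, a primary amide, a methyl ester, a plain alkyl group or a longer chain would give a number clearly apart from those of compound 1 and compound 3, or would join them in the same weak range.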